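This account rests on a few compounds, and the source may have more. Where it says the series, first, only, none or still open, it means among the compounds named here.

Of the compounds shown here, three on one shared core have been tested in a functional assay on K562 cells (Homo sapiens) for antiproliferative activity, with a stated time of 72 h; a higher number here means a weaker inhibitor, a lower number a stronger inhibitor. Compound 1 `OC[C@H]1O[C@@H](n2cnc3c(NCc4ccccc4F)ncnc32)[C@H](O)[C@@H]1O` gives 33200 nM in this assay. For compound 2 `Cc1ccc(CNc2ncnc3c2ncn3[C@@H]2O[C@H](CO)[C@@H](O)[C@H]2O)cc1` the result in this assay is only a limit of the assay, > 166000 nM. For compound 3 `COc1cccc(CNc2ncnc3c2ncn3[C@@H]2O[C@H](CO)[C@@H](O)[C@H]2O)c1OC` the result in this assay is likewise only a limit, > 166000 nM. Compound 3 thus stands beyond the reach of the measurement: the step of an at least 5.0-fold higher number from compound 1 to compound 3 (0.69 log units; beyond the scatter) is a clear weakening, and the step that the two limits leave unreadable from compound 2 to compound 3 cannot be read because both compounds sit at the limit of > 166000 nM in this assay, at which 2 of the 3 values shown sit. Compound 4 `OC[C@H]1O[C@@H](n2cnc3c(NCc4cc(O)cc(O)c4)ncnc32)[C@H](O)[C@@H]1O` differs from compound 3 in one place: 3,5-dihydroxyphenyl in place of 2,3-dimethoxyphenyl on a saturated chain carbon bound to a nitrogen on an aromatic ring. Among the measured compounds shown here, no measured step covers this exact change; the steps that touch the same place, an at least 5.0-fold higher number from compound 1 to compound 2 (0.69 log units; beyond the scatter) and an at least 5.0-fold higher number from compound 1 to compound 3 (0.69 log units; beyond the scatter), show that two replacements of the 2-fluorophenyl both weakened the compound. Compound 4 is therefore expected to remain weak, with an expected step of an at least 1.3-fold lower number from compound 3 to compound 4 (0.14 log units; that floor lies within the scatter) that may again end in a limit. The estimate for compound 4 is 120000 nM, between 30000 nM and 400000 nM.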

Compound 4, half-maximal inhibitory concentration: > 166000 nM
Compound 4: no number, only a limit; the forecaster's own chance of this, stated with the estimate: 55%; middle value at least 1.3-fold (0.14 log units) away from the limit.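

In this assay compound 4 again gives only a limit of the assay, > 166000 nM. Thus a third replacement of the 2-fluorophenyl, this one a 3,5-dihydroxyphenyl with hydrogen-bond donors that the 2,3-dimethoxyphenyl lacks, gives an at least 5.0-fold higher number from compound 1 to compound 4 (0.69 log units; beyond the scatter), so introducing these donors at this place does not bring a measurable value back. The steps among compound 2, compound 3 and compound 4 cannot be read, since all three share one limit: the limit of > 166000 nM in this assay, at which 3 of the 4 values shown sit.

From the compounds shown here alone, only compound 1 gives a number here, so it stays open whether a 2-chlorophenyl or an unsubstituted phenyl on the same saturated chain carbon would also give one. Going by these compounds, how far apart compound 2, compound 3 and compound 4 truly lie also remains unknown.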